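Replacing Neopentyl with 4-Chlorophenyl in a Receptor Agonist

This account rests on a few compounds, and the source may have more. Where it says the series, first, only, none or still open, it means among the compounds named here.

Compound 1, `CC(C)(C)CCc1cnc(CCc2ccc(-c3ccccc3C(=O)O)cc2)[nH]1`, 39 nM
Compound 2, `CCCCc1cnc(C(C)Cc2ccc(-c3ccccc3C(=O)O)cc2)[nH]1`, 2760 nM
Compound 3, `CCCCc1cnc(/C=C/c2ccc(-c3ccccc3C(=O)O)cc2)[nH]1`, 4380 nM

In an in vitro functional assay on cells for agonist activity at Bombesin receptor subtype-3 (Homo sapiens), read by luminescence and calcium flux (a higher number here means that more compound is needed for the effect, a lower number that less compound is needed), compound 1 gives 39 nM, the lowest of the three numbers; compound 2 gives 2760 nM and compound 3 gives 4380 nM, both well beyond the scatter from compound 1. Compound 4, `O=C(O)c1ccccc1-c1ccc(CCc2ncc(Cc3ccc(Cl)cc3)[nH]2)cc1`, differs from compound 1 in one place: 4-chlorophenyl in place of neopentyl on a saturated chain carbon bound to an aromatic carbon. Going by the values given here, no measured pair shows this exchange, so the step from compound 1 to compound 4 in this assay is expected to be small, in either direction, and possibly within the scatter. Compound 4 is therefore estimated at 60 nM, with a range from 15 nM to 300 nM, which means an expected step of a 1.5-fold higher number from compound 1 to compound 4 (0.19 log units; within the scatter).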

Compound 4, half-maximal effective concentration: 2290 nM
The estimate for compound 4 lay 38-fold (1.58 log units) below the measured number, and the stated range ends below it.
By their numbers in this assay, from the lowest: compound 1; then compounds 4, 2 and 3 (each within the scatter of the next).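

In this assay, 4-chlorophenyl in place of neopentyl on a saturated chain carbon bound to an aromatic carbon gives a 59-fold higher number from compound 1 to compound 4 (1.77 log units; beyond the scatter), so this position clearly does not treat the two groups alike. Compounds 2 and 3 each differ from compound 1 in more than one place, which makes this the first single change read here. Nothing measured here explains the size of this step. Going by these compounds, it remains open whether a benzyl group without the chlorine, or a cyclohexylmethyl group with its saturated ring, would give a number closer to that of compound 1 or to that of compound 4.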